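Replacing a Sulfonamide Methyl With Phenylcarbamoyl: Expected Response

The compounds below may be only part of what the source reports. "The series", "measured", "known", "first", "only" and "open" are said of these compounds alone.

Compound 1 `CNS(=O)(=O)c1ccc2c(c1)C(n1ccccc1=O)=CC(C)(C)O2` gives 85.8% in a functional assay on the whole organism (aorta) with Rattus norvegicus as the target; a higher number here means a larger maximal response, a lower number a smaller maximal response. Compound 2 `CC1(C)C=C(n2ccccc2=O)c2cc(S(=O)(=O)Nc3ccc(C#N)cc3)ccc2O1` gives 84% in this assay, so compound 1 and compound 2 lie within the scatter of each other. Compound 3 `CC1(C)C=C(n2ccccc2=O)c2cc(S(=O)(=O)NC(=O)Nc3ccccc3)ccc2O1` differs from compound 1 by phenylcarbamoyl in place of methyl on a sulfonamide nitrogen. Within the data shown here, the one measured step that bears on this, a number 1.8 percentage points lower from compound 1 to compound 2 (within the scatter), also exchanges that methyl for another group on the same nitrogen and stays within the scatter, so no step beyond the scatter is expected in this assay. Compound 3 is therefore estimated at 84%, in the range 70% to 96%, an expected step of a number 1.8 percentage points lower from compound 1 to compound 3 (within the scatter).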

Compound 3, largest response reached (Emax), in percent of the reference or control that the assay uses: 90.8%
For compound 3 the middle estimate is 6.8 percentage points below the measured one, and the stated range covers the measured number.
By their numbers in this assay, from the lowest: compounds 2, 1 and 3 (each within the scatter of the next).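

In this assay, phenylcarbamoyl in place of methyl on the sulfonamide nitrogen gives a number 5 percentage points higher from compound 1 to compound 3 (within the scatter), and phenylcarbamoyl in place of 4-cyanophenyl gives a number 6.8 percentage points higher from compound 2 to compound 3 (within the scatter). This position has therefore now carried a group that places a carbonyl on the nitrogen, as well as methyl and 4-cyanophenyl, with every step among these compounds within the scatter. Nothing shown here gives a reason for this. The compounds shown leave open whether a longer chain, or a carboxylic acid or an amine at the end of such a chain, would also stay within the scatter.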